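Swapping fluoro for methylsulfanyl on a boron-containing chalcone

The source may hold more compounds than are shown below. What is called first, only, known or untested is meant among the compounds shown, and "the series" means these compounds.

Compound 1 `O=C(/C=C/c1ccc2c(c1)B(O)OC2)c1cccnc1` gives 76200 nM in a toxicity assay on WI-38 cells (Homo sapiens) for cytotoxicity, read by MTT assay, with a stated time of 48 h; a higher number here means a weaker inhibitor, a lower number a stronger inhibitor. Compound 2 `O=C(/C=C/c1ccc2c(c1)B(O)OC2)c1ccc(F)cc1` gives 7600 nM, the lowest of the two numbers, after a 10-fold lower number from compound 1 to compound 2 (1.00 log units; beyond the scatter). Compound 3 `CSc1ccc(C(=O)/C=C/c2ccc3c(c2)B(O)OC3)cc1` differs from compound 2 only at the carbonyl-bearing ring: methylsulfanyl in place of fluoro on an aromatic carbon. Among the compounds with values here, the one measured step concerns a different change at the carbonyl, so no step bears directly on this swap. With nothing to point either way, compound 3 is expected to land close to compound 2, at 6000 nM, between 1500 nM and 24000 nM, a step of a 1.3-fold lower number from compound 2 to compound 3 (0.10 log units; within the scatter) that is estimated to stay within the scatter.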

Compound 3, half-maximal inhibitory concentration: 54300 nM
The estimate for compound 3 lay 9.1-fold (0.96 log units) below the measured number; the measured number lies above the stated range.
By their numbers in this assay, from the lowest: compound 2; then compounds 3 and 1 (each within the scatter of the next).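

In this assay, changing only the group on this aromatic carbon, with the rest of the molecule unchanged, gives a 7.1-fold higher number from compound 2 to compound 3 (0.85 log units; beyond the scatter). The earlier step exchanged a whole ring on the carbonyl, whereas this one shows that a single group on the ring, para to a large group, is enough to move the number beyond the scatter. Nothing available explains why this swap has such an effect.

Going by these compounds, whether other groups at this carbon, such as methoxy, an amine or a carboxylic acid, would behave more like fluoro or more like methylsulfanyl remains open.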